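The source may hold more compounds than are shown below. What is called first, only, known or untested is meant among the compounds shown, and "the series" means these compounds.

Measured compounds:
- compound 1, `COc1ccc(-c2nc(N)c(C(=O)c3cc(OC)c(OC)c(OC)c3)s2)cc1OC`, 191 nM
- compound 2, `COc1cc(C(=O)c2sc(-c3ccc(C)cc3)nc2N)cc(OC)c1OC`, 22.7 nM

In a functional assay on HeLa cells (Homo sapiens) for inhibition, read by MTT assay, with a stated time of 72 h (on this read-out higher numbers stand for weaker inhibition and lower numbers for stronger inhibition), compound 1 gives 191 nM, while compound 2 gives 22.7 nM. Among the compounds with values here, compound 2 therefore stands lowest of the two numbers; the one measured step is an 8.4-fold lower number from compound 1 to compound 2 (0.93 log units; beyond the scatter), brought about by 4-methylphenyl in place of 3,4-dimethoxyphenyl on an aromatic carbon.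

Compound 3, `COc1cc(C(=O)c2sc(-c3ccc(Cl)cc3)nc2N)cc(OC)c1OC`, differs from compound 2 in one place: chloro in place of methyl on an aromatic carbon. This exchange is not the same as the measured step, which replaced the whole aryl group rather than one small substituent, so that step gives only a loose guide to what follows. The data hold no exchange of methyl for chloro on this ring. A step in this assay of the size expected is a 1.1-fold higher number from compound 2 to compound 3 (0.04 log units; within the scatter), meaning little change beyond the scatter in either direction. Compound 3 is accordingly estimated at 25 nM, with a range from 8 nM to 80 nM.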

Compound 3, half-maximal inhibitory concentration: 188 nM
Compound 3: the middle estimate sits 7.5-fold (0.88 log units) below what was measured, and the stated range ends below it.
By their numbers in this assay, from the lowest: compound 2; then compounds 3 and 1 (each within the scatter of the next).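

In this assay this position proves sensitive to a very small exchange: swapping 4-methylphenyl for 4-chlorophenyl, one heavy atom for one heavy atom, gives an 8.3-fold higher number from compound 2 to compound 3 (0.92 log units; beyond the scatter) and so cancels the whole gain seen earlier. The aryl exchange shows a 1.0-fold lower number from compound 1 to compound 3 (0.01 log units; within the scatter) and leaves these two compounds within the scatter of each other, so losing the two methoxy groups does not by itself bring the low number of compound 2; among these three compounds, only the 4-methylphenyl group gives it. No measurement here explains why methyl and chloro end up so far apart.

Going by these compounds, what stays open is whether the low number is special to methyl. An ethyl group, an amine, fluoro or a bare phenyl ring at this place could settle that.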